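Ester Chain Length and Cell Viability Across Four Analogues

The source may hold more compounds than are shown below. What is called first, only, known or untested is meant among the compounds shown, and "the series" means these compounds.

Measured compounds:
compound 1, `CCCCCCOC(=O)CCC(=O)N1CCN(CCCOc2cc3c(Nc4ccc(F)c(Cl)c4)ncnc3cc2OC)CC1`: 89.3%
compound 2, `CCCCCCCOC(=O)CCC(=O)N1CCN(CCCOc2cc3c(Nc4ccc(F)c(Cl)c4)ncnc3cc2OC)CC1`: 89.1%
compound 3, `CCCCCCCCCCCOC(=O)CCC(=O)N1CCN(CCCOc2cc3c(Nc4ccc(F)c(Cl)c4)ncnc3cc2OC)CC1`: 93.4%

Three compounds sharing one core and differing only in the length of the ester chain have been tested in a functional assay on A549 cells (Homo sapiens) for cytotoxicity, read by MTT assay, with a stated time of 24 h, tested at 10 uM; a higher number here means a weaker effect of the compound at the concentration tested, a lower number a stronger effect. In this assay compound 1 gives 89.3%, compound 2 gives 89.1% and compound 3 gives 93.4%. The change from compound 1 to compound 2 is methyl in place of hydrogen on a saturated chain carbon, six bonds along the chain from an oxygen next to a carbonyl group, and its step was a number 0.2 percentage points lower from compound 1 to compound 2 (within the scatter). The longer extension, (pentyl in place of hydrogen on a saturated chain carbon, six bonds along the chain from an oxygen next to a carbonyl group), gave a number 4.1 percentage points higher from compound 1 to compound 3 (within the scatter), and from compound 2 to compound 3 the step was a number 4.3 percentage points higher from compound 2 to compound 3 (within the scatter). Within the data shown here, all three values lie within the usual scatter of one another, so no compound can be called stronger or weaker here.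

Compound 4, `CCCCCCCCCCCCOC(=O)CCC(=O)N1CCN(CCCOc2cc3c(Nc4ccc(F)c(Cl)c4)ncnc3cc2OC)CC1`, has not yet been measured. It differs from compound 3 by methyl in place of hydrogen on a saturated chain carbon, ten or more bonds along the chain from an oxygen next to a carbonyl group. Among the measured compounds shown here, this is the same kind of change as the one from compound 1 to compound 2, but not at the same place along the chain; the two differences as given each name their own place. The cores of compound 1 and compound 3 differ by pentyl in place of hydrogen on a saturated chain carbon, six bonds along the chain from an oxygen next to a carbonyl group only.

Given that every change of chain length among compounds 1, 2 and 3 stayed within the scatter, compound 4 is expected to show a step of about a number 1.4 percentage points lower from compound 3 to compound 4 (within the scatter), again within the scatter, because compound 3 already gives 93.4%. The estimate for compound 4 in this assay is 92%, with a range from 84% to 99%.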

Compound 4, a percentage reported as activity, at one concentration (the size of the read-out at that concentration, not a potency): 95.5%
The estimate for compound 4 lay 3.5 percentage points below the measured number, within the range that was stated.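

In this assay, methyl in place of hydrogen gave a number 2.1 percentage points higher from compound 3 to compound 4 (within the scatter), and set beside the same change on the shorter chain, it showed no difference between the two cores: the same change on two cores in this assay, a number 0.2 percentage points lower (within the scatter) from compound 1 to compound 2 and a number 2.1 percentage points higher (within the scatter) from compound 3 to compound 4, 2.3 percentage points apart, within the scatter of two such steps The larger extensions read alike, with hexyl giving a number 6.2 percentage points higher from compound 1 to compound 4 (within the scatter) and pentyl giving a number 6.4 percentage points higher from compound 2 to compound 4 (within the scatter), and the pentyl step agreed with the earlier one on the other core: the same change on two cores in this assay, a number 4.1 percentage points higher (within the scatter) from compound 1 to compound 3 and a number 6.4 percentage points higher (within the scatter) from compound 2 to compound 4, 2.3 percentage points apart, within the scatter of two such steps Within these four compounds, therefore, lengthening the ester chain carried from one core to another without any visible shift, but as every step lies within the scatter, this shows only that no effect of the change could be detected at the one concentration tested, not that an effect of measurable size would transfer in the same way.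

The compounds shown leave open how a chain shorter than the hexyl ester or longer than that of compound 4 would behave in this assay. They also leave open whether a carboxylic acid or an amide in place of the ester, or a ring or an amine at the end of the chain, would move the read-out beyond the scatter.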